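Swapping Bromine for Chlorine on the Shared Core

The source may report more compounds than this note shows. Statements on the series, on what has been measured and on what is new or still open speak of the compounds shown alone.

Among the measured compounds shown here, compound 1 `Brc1ccc(C2=NN(C3=NC(c4ccccc4)CS3)C(c3ccc4ccccc4c3)C2)cc1` is one of three compounds measured in a functional assay on HeLa cells (Homo sapiens) for inhibition, read by CCK-8 assay, with a stated time of 48 h; on this read-out higher numbers stand for weaker inhibition and lower numbers for stronger inhibition. In this assay compound 1 gives 4960 nM, the highest of the three numbers, yet compound 2 `O=C1CSC(N2N=C(c3ccc(Br)cc3)CC2c2ccc3ccccc3c2)=N1` gives 4220 nM and compound 3 `Cc1ccc(C2=NN(C3=NC(=O)CS3)C(c3cccc4ccccc34)C2)cc1` gives 3210 nM, both within the usual scatter of compound 1, so no order among the three can be read. For the measured compounds named here, the only step between close neighbours, a 1.2-fold lower number from compound 1 to compound 2 (0.07 log units; within the scatter), exchanges a larger group for a smaller one on the ring nitrogen and stays within the scatter.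

Compound 4 `Clc1ccc(C2=NN(C3=NC(c4ccccc4)CS3)C(c3ccc4ccccc4c3)C2)cc1` differs from compound 1 in one place: chloro in place of bromo on an aromatic carbon. Going by the values given here, no measured step touches this position; compounds 1 and 2 share the same 4-bromophenyl group, and compound 3 carries a different group there without a single-point comparison. With nothing to point either way, the step from compound 1 to compound 4 is expected to be a 1.0-fold higher number from compound 1 to compound 4 (0.00 log units; within the scatter), none beyond the scatter. Compound 4 is therefore estimated at 5000 nM, with a range from 2500 nM to 10000 nM.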

Compound 4, half-maximal inhibitory concentration: 7560 nM
Compound 4: middle estimate off by 1.5-fold (0.18 log units), on the low side; the measured number falls inside the stated range.
By their numbers in this assay, from the lowest: compounds 3, 2, 1 and 4 (each within the scatter of the next, the first and the last beyond it).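

Among the compounds shown here, the exchange of bromo for chloro is the first change at this position that can be read on its own, and in this assay it gives a 1.5-fold higher number from compound 1 to compound 4 (0.18 log units; within the scatter) without leaving the scatter. On this aromatic carbon, para to a large group, the exchange therefore does not separate the two compounds, and no order between bromo and chloro can be read from this single pair. No data shown here offer any explanation for this result.

Still open, going by these compounds, is whether a different kind of group on this carbon, such as an amine, a methoxy group or a carboxylic acid, would move the number beyond the scatter. Also open, on these data alone, is whether the same exchange of bromo for chloro would read the same way on compound 2, which carries a smaller group on the ring nitrogen.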